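Notes: ethynyl in place of methyl, compound 3 to compound 4

This account rests on a few compounds, and the source may have more. Where it says the series, first, only, none or still open, it means among the compounds named here.

Measured so far in a functional assay on MDA-MB-231 cells (Homo sapiens) for antiproliferative activity, read by MTT assay, with a stated time of 72 h; on this read-out higher numbers stand for weaker inhibition and lower numbers for stronger inhibition:
- compound 1 `CC(=O)Nc1ccc(S(=O)(=O)Nc2cccc(-c3nc(-c4ccc(NC(=O)c5cccnc5)cc4Cl)no3)c2)cc1C`: > 10000 nM, a limit of the assay
- compound 2 `CCNC(=O)Nc1ccc(S(=O)(=O)Nc2cccc(-c3nc(-c4ccc(NC(=O)c5cccnc5)cc4Cl)no3)c2)cc1`: 3100 nM
- compound 3 `Cc1ccc(NC(=O)Nc2cccc(-c3nc(-c4ccc(NC(=O)c5cccnc5)cc4Cl)no3)c2)cc1`: 3500 nM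

Compound 3 stands highest of the two numbers shown, but its nearest neighbour, compound 2, lies within the scatter of it, so no order between the two can be read. For the measured compounds named here, the one measured step is an at least 3.2-fold lower number from compound 1 to compound 2 (0.50 log units; beyond the scatter), and it changes the group on the sulfonyl sulfur; compound 1 sits at the limit (the limit of > 10000 nM in this assay, at which 1 of the 3 values shown sits), so only a bound is known for that step.

Compound 4 `C#Cc1ccc(NC(=O)Nc2cccc(-c3nc(-c4ccc(NC(=O)c5cccnc5)cc4Cl)no3)c2)cc1` is not yet measured. Against compound 3 the change is ethynyl in place of methyl on an aromatic carbon. Going by the values given here, no measured step touches this part of the molecule; the change is small, and neither hydrogen-bond donors nor acceptors are counted in or out. No step beyond the scatter is therefore expected in this assay. Compound 4 is expected to give 3500 nM, with a range from 1500 nM to 8000 nM. The expected step is no change at the digits printed from compound 3 to compound 4 (within the scatter).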

Compound 4, half-maximal inhibitory concentration: > 10000 nM
Compound 4 gave a limit, no number; the forecaster's own chance of this, stated with the estimate: 10%; at least 2.8-fold (0.45 log units) between middle value and limit.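

In this assay, ethynyl in place of methyl on this aromatic carbon gives an at least 2.8-fold higher number from compound 3 to compound 4 (0.45 log units; beyond the scatter), so the position is not indifferent to a change this small. For the compounds shown here, the earlier compounds could not show this, as their one measured step lies on the sulfonyl sulfur and leaves this part of the molecule untouched. Compound 4 gives > 10000 nM, which is a limit of the assay, so the step is only a bound: the limit of > 10000 nM in this assay, at which 2 of the 4 values shown sit.

Open, going by these compounds, is how this position responds to other groups: an ethyl, a chlorine, a methoxy or an amine in place of methyl would show whether ethynyl stands alone here. Also open, on these data alone, is whether a nitrile, which carries a triple bond of its own, reads as ethynyl does.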